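Ether chain variation on the shared core

The source may hold more compounds than are shown below. What is called first, only, known or untested is meant among the compounds shown, and "the series" means these compounds.

The series keeps one core and differs only in the group on the oxygen of the aromatic ring. Compound 1 `CCCCCCCCOc1ccc2c(Cl)ccnc2c1` carries an octyl chain and gives 3640 nM in a functional assay on RKO cells (Homo sapiens) for cytotoxicity, read by MTT assay, with a stated time of 48 h; a higher number here means a weaker inhibitor, a lower number a stronger inhibitor. Compound 2 `CCCCCCOc1ccc2c(Cl)ccnc2c1` carries a hexyl chain, and in this assay compound 2 gives 2720 nM. Compound 3 `Clc1ccnc2cc(OCCc3ccccc3)ccc12` carries a phenethyl group, and in this assay compound 3 gives 2560 nM. Compound 2 stands second highest of the measured values; its nearest neighbour is compound 3 and its furthest is compound 1, and both gaps are within the scatter.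

Compound 4 `C=CCOc1ccc2c(Cl)ccnc2c1` differs from compound 2 by vinyl in place of pentyl on a saturated chain carbon bound to an oxygen on an aromatic ring. Two kinds of measured step bear on this change. Shortening the chain, a 1.3-fold lower number from compound 1 to compound 2 (0.13 log units; within the scatter), produced nothing beyond the scatter. Replacing alkyl by phenyl at the chain end, a 1.4-fold lower number from compound 1 to compound 3 (0.15 log units; within the scatter) and a 1.1-fold lower number from compound 2 to compound 3 (0.03 log units; within the scatter), also stayed within the scatter. Every change on this chain so far has left the number essentially unchanged, so no step beyond the scatter is expected here either, in either direction. The expected step is a 1.1-fold higher number from compound 2 to compound 4 (0.04 log units; within the scatter). Compound 4 is therefore expected to give about 3000 nM, with a range from 1200 nM to 8000 nM.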

Compound 4, half-maximal inhibitory concentration: 2460 nM
Beside the measured number, compound 4's estimate is 1.2-fold (0.09 log units) above it; measured number inside the range.
By their numbers in this assay, from the lowest: compounds 4, 3, 2 and 1 (each within the scatter of the next).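

Replacing pentyl with vinyl on the saturated chain carbon bound to the oxygen on the aromatic ring, which turns hexyl into allyl, gives a 1.1-fold lower number from compound 2 to compound 4 (0.04 log units; within the scatter) in this assay. This extends the earlier picture in two ways: the chain can be much shorter than hexyl, and it can carry a double bond outside the aromatic rings, without a step beyond the scatter. Together with the octyl, hexyl and phenethyl compounds, allyl shows that neither chain length nor this unsaturated end has yet produced a measurable step at this position, and nothing available explains why the number stays so flat across these groups.

The compounds shown leave open whether any group on this oxygen can move the number beyond the scatter, for example a chain ending in an amine or a carboxylic acid. They also leave open whether the same flat picture holds at the short extreme, with a methyl group on the oxygen or with a free hydroxyl in place of the ether.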